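Ring closure of the dialkylamino group: piperidinyl analogue

A few compounds are considered here, and "the series" means these few. Any claim that something is new, unique, unknown or untested is made for them only; others in the source may bear on it.

Measured so far:
- compound 1 `CCCCCCCCCCCCCC[C@H](OCOC)[C@H](CN(C(C)C)C(C)C)NC(=O)OC(C)(C)C`, in a functional assay on MDA-MB-231 cells (Homo sapiens) for antiproliferative activity, read by sulforhodamine B assay, with a stated time of 48 h, tested at 10 uM (a higher number here means more inhibition at the concentration tested (going by the name of the read-out), a lower number less inhibition), compound 1 gives 31%
- compound 2 `CCCCCCCCCCCCCC[C@H](OCOC)[C@H](CN(CCCC)CCCC)NC(=O)OC(C)(C)C`, in this assay compound 2 gives 22.3%

Within the data shown here, compound 2 holds the lower of the two values, but the single measured step, a number 8.7 percentage points lower from compound 1 to compound 2 (within the scatter), lies within the scatter, so the two compounds are not separated by this read-out.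

Compound 3 `CCCCCCCCCCCCCC[C@H](OCOC)[C@H](CN1CCCCC1)NC(=O)OC(C)(C)C` differs from compound 2 by piperidin-1-yl in place of dibutylamino on a saturated chain carbon, two bonds along the chain from an amide-type nitrogen. Among the measured compounds shown here, the only step that bears on this change is the amine exchange at the same place, a number 8.7 percentage points lower from compound 1 to compound 2 (within the scatter), which did not move the number beyond the scatter. The change from compound 2 to compound 3 is another exchange of the amine at that carbon, with nothing measured that points in either direction. The expected step is therefore a number 2.7 percentage points higher from compound 2 to compound 3 (within the scatter), none beyond the scatter. For compound 3 the estimated value in this assay is 25%, with a range from 10% to 42%.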

Compound 3, a percentage reported as inhibition, at one concentration (the size of the read-out at that concentration, not a potency): 9.84%
Beside the measured number, compound 3's estimate is 15.2 percentage points above it, outside the stated range (below it).
By their numbers in this assay, from the lowest: compound 3; then compounds 2 and 1 (each within the scatter of the next).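

In this assay, among these compounds, closing the amine into piperidin-1-yl is the first change at this saturated chain carbon to move the number beyond the scatter, with a number 12.5 percentage points lower from compound 2 to compound 3 (beyond the scatter) and a number 21.2 percentage points lower from compound 1 to compound 3 (beyond the scatter). The read-out therefore does respond to the amine at this place: the two open-chain amines of compound 1 and compound 2 are not separated, whereas compound 3 falls beyond the scatter of both. No available evidence explains this drop.

With a single ring compound in the set, the drop cannot yet be assigned to the ring itself rather than to the smaller group with fewer heavy atoms. An open-chain diethylamino group of similar size, or a pyrrolidin-1-yl or morpholin-4-yl ring at the same carbon, would help to separate these two readings.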